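A few compounds are considered here, and "the series" means these few. Any claim that something is new, unique, unknown or untested is made for them only; others in the source may bear on it.

Compound 1 `CC(/C=N/Nc1ccc([N+](=O)[O-])cc1)=N\NC(=O)c1ccccc1Cl`. In a functional assay on cells (Splenocyte, Mus musculus, strain BALB/c) for inhibition, read by scintillation counting and thymidine incorporation, with a stated time of 72 h (a higher number here means a weaker inhibitor, a lower number a stronger inhibitor), compound 1 gives only a limit, > 12000 nM.
Compound 2 `CC(/C=N/Nc1ccc([N+](=O)[O-])cc1)=N\NC(=O)c1ccccc1O`. In this assay compound 2 gives 1640 nM.
Compound 3 `CC(/C=N/Nc1ccc([N+](=O)[O-])cc1)=N\NC(=O)c1ccc(C(C)(C)C)cc1`. In this assay compound 3 gives only a limit, > 12000 nM.

Compound 1 therefore sits at the edge of what this assay can report: a limit rather than a number, and the limit of > 12000 nM in this assay, at which 2 of the 3 values shown sit, shows that compound 3 stands there as well. Among the compounds with values here, only compound 2 has a measured value, reached through the single step that has been worked out, an at least 7.3-fold lower number from compound 1 to compound 2 (0.86 log units; beyond the scatter).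

The new compound is compound 4 `CC(/C=N/Nc1ccc([N+](=O)[O-])cc1)=N\NC(=O)c1ccc(N(C)C)cc1`. It differs from compound 1 as 4-(dimethylamino)phenyl in place of 2-chlorophenyl on a carbonyl carbon. Within the data shown here, the one measured step, from compound 1 to compound 2, changes a group on the same ring, but it introduces a hydroxy, which is not what enters here, so it bears on the present step only loosely. Among the measured compounds shown here, compound 3, which carries a different group on the same phenyl ring, stays at the limit in this assay, and no step to it has been worked out. Without a closer comparison, compound 4 is expected to stay near the limit, so the step of a number no higher from compound 1 to compound 4 (the limit leaves the size open) is estimated to be none beyond the scatter. For compound 4 in this assay the estimate is 12000 nM, within 3000 nM to 40000 nM.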

Compound 4, half-maximal inhibitory concentration: > 12000 nM
Compound 4 ended at the assay's limit; the forecaster's own chance of this, stated with the estimate: 65%; the middle value lies on the limit itself.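

With this change, the 4-(dimethylamino)phenyl on the carbonyl carbon gives an at least 7.3-fold higher number from compound 2 to compound 4 (0.86 log units; beyond the scatter). Compound 2 therefore remains the only compound shown with a measured number, while dimethylamino on the ring joins chloro and tert-butyl at the edge of what the assay reports: the limit of > 12000 nM in this assay, at which 3 of the 4 values shown sit. The steps that link compound 4 to compound 1 and to compound 3 cannot be read, since each has a limit at both ends, so these three compounds cannot be ranked against one another.

Compounds 2 and 4 differ in both the group on the ring and where it sits, which leaves open whether the gain in compound 2 belongs to the hydroxy itself or to its place as part of the 2-hydroxyphenyl. A hydroxy in the place of the dimethylamino of compound 4 would separate the two, and a methoxy or an amine in the place of the hydroxy of compound 2 would show how far the measured value depends on that particular group.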